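Series notes: dichlorophenyl in place of fluorophenyl

This account rests on a few compounds, and the source may have more. Where it says the series, first, only, none or still open, it means among the compounds named here.

The compounds share one core and differ only in the aryl group on the double-bonded chain. Compound 1 `CNC(=O)c1cc(Oc2ccc(/C=C/C(=O)c3ccc(C)cc3)cc2)ccn1` gives > 50000 nM in a functional assay on HepG2 cells (Homo sapiens) for cytotoxicity, read by MTT assay, with a stated time of 72 h (a lower number here means a stronger inhibitor, a higher number a weaker inhibitor), which is a limit of the assay rather than a number (the limit of > 50000 nM in this assay, at which 1 of the 3 values shown sits). Compound 2 `CNC(=O)c1cc(Oc2ccc(C(=O)/C=C/c3ccc(F)cc3)cc2)ccn1` gives 12600 nM in this assay, the highest of the two numbers recorded. Compound 3 `CNC(=O)c1cc(Oc2ccc(C(=O)/C=C/c3ccc(OC)c(OC)c3OC)cc2)ccn1` gives 9810 nM in this assay, which sits within the usual scatter of compound 2, so no order between compound 2 and compound 3 can be read. Among the compounds with values here, no step between two measured compounds that differ in a single place is available in this set. Compound 4 `CNC(=O)c1cc(Oc2ccc(C(=O)/C=C/c3cccc(Cl)c3Cl)cc2)ccn1` has not yet been measured. Its difference from compound 2 is 2,3-dichlorophenyl in place of 4-fluorophenyl on a double-bonded chain carbon bound to a double-bonded chain carbon. Within the data shown here, with no comparable step to rest on, and with compound 2 and compound 3 close to each other despite carrying different aryl groups, the change is expected to move the number little, possibly within the scatter, with weak cytotoxicity retained. Compound 4 is therefore expected to give 10000 nM in this assay, with a range from 3500 nM to 30000 nM. The expected step from compound 2 to compound 4 is a 1.3-fold lower number from compound 2 to compound 4 (0.10 log units; within the scatter).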

Compound 4, half-maximal inhibitory concentration: > 50000 nM
Compound 4 was reported as a limit; the forecaster's own chance of this, stated with the estimate: 12%; at least 5.0-fold (0.69 log units) between middle value and limit.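

In this assay, 2,3-dichlorophenyl in place of 4-fluorophenyl on a double-bonded chain carbon bound to a double-bonded chain carbon gives an at least 3.9-fold higher number from compound 2 to compound 4 (0.59 log units; beyond the scatter). Within the data shown here, compound 2 and compound 3 lie within the scatter of each other despite their different aryl groups, so this is the first reading to show that the aryl group at this position can shift the result beyond the scatter, and toward weaker inhibition. Compound 4 gives > 50000 nM, which is a limit of the assay and not a number, so the step fixes only a minimum size, and this limit is no longer confined to a single compound: the limit of > 50000 nM in this assay, at which 2 of the 4 values shown sit.

The compounds shown leave open which part of the change carries the shift, whether the presence of chlorine, the number of chlorines or their placement, as no compound here alters one of these alone. Also open, as far as these compounds go, is how a phenyl group carrying one chlorine, or a phenyl group carrying a carboxylic acid, would read at this position in this assay.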